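A few compounds are considered here, and "the series" means these few. Any claim that something is new, unique, unknown or untested is made for them only; others in the source may bear on it.

Measured compounds in an assay on isolated protein for inhibition of myosin-2 (Bos taurus), read by spectrophotometry, with a stated time of 24 min; on this read-out lower numbers stand for stronger inhibition and higher numbers for weaker inhibition:
Compound 1 `C/C(=N\CCO)c1c(O)c2ccccc2[nH]c1=O` gives only a limit, >= 100000 nM.
Compound 2 `CCC(C)/N=C(\C)c1c(O)c2ccccc2oc1=O` gives only a limit, >= 100000 nM.
Compound 3 `C/C(=N\OCc1ccccc1)c1c(O)c2ccccc2oc1=O` gives only a limit, >= 100000 nM.

Compound 2 thus stands where every measured value stands, at the limit of this assay and not at a number; the relevant evidence is the limit of >= 100000 nM in this assay, at which 3 of the 3 values shown sit. No step between measured compounds is available, so nothing shown tells how a change on the double-bonded nitrogen moves the read-out.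

Compound 4 `CCCCC/N=C(\C)c1c(O)c2ccccc2oc1=O` is the next member, not yet measured. It differs from compound 2 by pentyl in place of sec-butyl on a double-bonded nitrogen.

Given that compound 2 and the other two measured members all sit at the limit, no step beyond the scatter is expected in this assay, neither stronger nor weaker, and the step from compound 2 to compound 4 is estimated as a number no higher from compound 2 to compound 4 (the limit leaves the size open). Compound 4 is expected to give 100000 nM, with a range from 30000 nM to 300000 nM, most likely reported again as a limit.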

Compound 4, half-maximal inhibitory concentration: 6700 nM
Estimate against measurement, compound 4: 15-fold (1.17 log units) above; the whole stated range lies above it.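

In this assay, the group on the double-bonded nitrogen can move the read-out: pentyl in place of sec-butyl gives an at least 14-fold lower number from compound 2 to compound 4 (1.17 log units; beyond the scatter). Compound 4 is the first compound shown to give a number rather than a limit, so this position is not silent in this assay. Compound 2 remains a limit, so the full size of the step stays open: the limit of >= 100000 nM in this assay, at which 3 of the 4 values shown sit.

The pair alone cannot separate chain length from branching. Butyl, hexyl or a longer chain would test this, and a terminal amine on the pentyl chain would show whether the chain end tolerates change.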